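The source may report more compounds than this note shows. Statements on the series, on what has been measured and on what is new or still open speak of the compounds shown alone.

Going by the values given here, in a functional assay on PC-3 cells (Homo sapiens) for antiproliferative activity, read by MTT assay (on this read-out lower numbers stand for stronger inhibition and higher numbers for weaker inhibition), compound 1 `Cn1c(=O)c(=O)n(C2CCCC2)c2nc(N/N=C/c3ccc(F)c(Cl)c3)ncc21` gives 8550 nM, the lowest of the three numbers measured so far. Compound 2 `Cc1ccc(/C=N/Nc2ncc3c(n2)n(C2CCCC2)c(=O)c(=O)n3C)cc1C` gives 39000 nM, and compound 3 `Cn1c(=O)c(=O)n(C2CCCC2)c2nc(N/N=C/c3ccc(F)cc3F)ncc21` gives 13200 nM. Compound 4 `Cn1c(=O)c(=O)n(C2CCCC2)c2nc(N/N=C/c3ccccc3Cl)ncc21` differs from compound 1 only in the group on the carbon with a double bond to nitrogen: 2-chlorophenyl in place of 3-chloro-4-fluorophenyl on a carbon with a double bond to nitrogen. Among the compounds with values here, two measured steps bear on this change, each swapping that same group: a 4.6-fold higher number from compound 1 to compound 2 (0.66 log units; beyond the scatter) and a 1.5-fold higher number from compound 1 to compound 3 (0.19 log units; within the scatter). Both moved the number upward, one clearly and one within the scatter, so a small to modest rise is expected here as well. Compound 4 is therefore estimated at 12000 nM in this assay, with a likely range of 5000 nM to 30000 nM, an expected step of a 1.4-fold higher number from compound 1 to compound 4 (0.15 log units; within the scatter).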

Compound 4, half-maximal inhibitory concentration: 16300 nM
For compound 4 the middle estimate is 1.4-fold (0.13 log units) below the measured one; the range from low to high includes it.
By their numbers in this assay, from the lowest: compounds 1, 3 and 4 (each within the scatter of the next); then compound 2.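

With 2-chlorophenyl at this position, compound 4 stays within the scatter of both other halogen-bearing compounds in this assay (a 1.9-fold higher number from compound 1 to compound 4 (0.28 log units; within the scatter); a 1.2-fold higher number from compound 3 to compound 4 (0.09 log units; within the scatter)), yet clears the scatter against the 3,4-dimethylphenyl compound (a 2.4-fold lower number from compound 2 to compound 4 (0.38 log units; beyond the scatter)). Among these four compounds, the three halogen-bearing phenyl groups therefore form one group, with compound 2 alone outside it. No measurement given here explains this pattern. Still open, as far as these compounds go, is whether an unsubstituted phenyl, a methoxyphenyl or an aminophenyl group would sit with the halogen-bearing compounds or with compound 2.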